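The source may hold more compounds than are shown below. What is called first, only, known or untested is meant among the compounds shown, and "the series" means these compounds.

Measured compounds: compound 1 `N=c1oc2ccc(Br)cc2cc1C(=O)NCC(O)CO`, compound 2 `O=C(NC1CCCC1)c1cc2ccccc2oc1=O`, compound 3 `N=c1oc2ccc(Br)cc2cc1C(=O)NCCO`.

In an assay on HeLa cells for displacement of a labelled ligand from adenosine receptor A3 (Homo sapiens), read by scintillation counting, with a stated time of 180 min, tested at 10 uM (on this read-out higher numbers stand for more inhibition at the one concentration tested (going by the name of the read-out) and lower numbers for less inhibition), compound 2 gives 20%, the highest of the three numbers, although its gap to compound 1, which gives 10%, lies within the scatter, while its gap to compound 3, which gives 0%, lies beyond it. Compound 4 `O=C(NCCCO)c1cc2ccccc2oc1=O` is not yet measured. It differs from compound 2 by 3-hydroxypropyl in place of cyclopentyl on an amide-type nitrogen, so a ring of carbon only gives way to a chain carrying a hydroxyl.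

Within the data shown here, one measured step bears on this: compound 1 and compound 3 share a core and differ only in the chain on the amide nitrogen, and the change from the longer to the shorter chain gave a number 10 percentage points lower from compound 1 to compound 3 (within the scatter). A change of an amide-nitrogen chain bearing a hydroxyl thus left this assay essentially unmoved. Among the measured compounds shown here, no measured pair swaps a ring for such a chain, so the expectation rests on this alone.

Compound 4 is therefore expected to give about 12%, between -5% and 28%, a step of a number 8 percentage points lower from compound 2 to compound 4 (within the scatter), not beyond the scatter.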

Compound 4, a percentage reported as inhibition, at one concentration (the size of the read-out at that concentration, not a potency): 6%
For compound 4 the middle estimate is 6 percentage points above the measured one; low and high end bracket the measured number.
By their numbers in this assay, from the lowest: compounds 3, 4, 1 and 2 (each within the scatter of the next, the first and the last beyond it).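

In this assay, 3-hydroxypropyl in place of cyclopentyl on an amide-type nitrogen gives a number 14 percentage points lower from compound 2 to compound 4 (beyond the scatter) as a modest step. Among these compounds, this is the first step at this position that goes beyond the scatter, and it is also the first exchange of a ring of carbon only for a chain carrying a hydroxyl. The earlier chain change gave only a number 10 percentage points lower from compound 1 to compound 3 (within the scatter) on a different core, so the two steps cannot be set directly against each other, and nothing measured here explains the new one.

As far as these compounds go, it stays open whether a plain propyl chain without the hydroxyl would match compound 2 or compound 4, which would separate the effect of removing the ring from that of adding the hydroxyl. A chain carrying an amine or a carboxylic acid in place of the hydroxyl also remains untested among the compounds shown.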